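A few compounds are considered here, and "the series" means these few. Any claim that something is new, unique, unknown or untested is made for them only; others in the source may bear on it.

Measured in a functional assay on SMMC-7721 cells (Homo sapiens) for antiproliferative activity, read by MTT assay, with a stated time of 48 h; on this read-out lower numbers stand for stronger inhibition and higher numbers for weaker inhibition:
- compound 1 `Cn1cc(C2=C(c3nn(CCCn4ccnc4)c4ncccc34)C(=O)N(c3ccccc3)C2=O)c2ccccc21`: 34800 nM
- compound 2 `Cn1cc(C2=C(c3nn(CCCN4CCCCC4)c4ncccc34)C(=O)N(c3ccccn3)C2=O)c2ccccc21`: > 100000 nM (a limit)
- compound 3 `Cn1cc(C2=C(c3nn(CCCn4ccnc4)c4ncccc34)C(=O)NC2=O)c2ccccc21`: > 100000 nM (a limit)

Compound 3 stands at > 100000 nM, which is a limit of the assay and not a number. The set as a whole shows (the limit of > 100000 nM in this assay, at which 2 of the 3 values shown sit).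

The next structure is compound 4 `Cn1cc(C2=C(c3nn(CCCO)c4ncccc34)C(=O)NC2=O)c2ccccc21`, with hydroxy in place of 1H-imidazol-1-yl on a saturated chain carbon, three bonds along the chain from an aromatic nitrogen.

For the measured compounds named here, the only measured step that touches this comparison is an at least 2.8-fold higher number from compound 1 to compound 3 (0.45 log units; beyond the scatter), for hydrogen in place of phenyl on an amide-type nitrogen in a ring. Compound 4 keeps that hydrogen, so the reading in this assay is expected to stay in the weak region reached by compound 3. Going by the values given here, that step says nothing directly about the end of the chain, and no measured step covers a change there. With no number for compound 3, no direction can be argued, and no change beyond the scatter is expected.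

The step expected is a number no higher from compound 3 to compound 4 (the limit leaves the size open). For compound 4 the estimated value is 100000 nM, with an expected range of 35000 nM to 300000 nM, and a report as a limit only is likely.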

Compound 4, half-maximal inhibitory concentration: > 100000 nM
Compound 4 gave a limit, no number; the forecaster's own chance of this, stated with the estimate: 70%; the middle value sits exactly at the limit.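

In this assay compound 4 gives > 100000 nM, a limit and not a number. Compound 3 gives > 100000 nM, also a limit, so no step can be read between compound 3 and compound 4. The compounds shown leave open whether hydroxy and 1H-imidazol-1-yl differ at all on this chain, as most readings rest at one value: the limit of > 100000 nM in this assay, at which 3 of the 4 values shown sit.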